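The source may report more compounds than this note shows. Statements on the series, on what has been measured and on what is new or still open speak of the compounds shown alone.

Compound 2 `O=C(CSc1cccc(O)c1)Nc1ccc2nc(NC(=O)c3ccc(C(F)(F)F)cc3)sc2c1` gives the lower of the two numbers in a functional assay on U2OS cells (Homo sapiens) for antiproliferative activity, read by MTT assay, with a stated time of 72 h (a higher number here means a weaker inhibitor, a lower number a stronger inhibitor), at 630 nM; compound 1 `O=C(CSc1ncccn1)Nc1ccc2nc(NC(=O)c3ccc(C(F)(F)F)cc3)sc2c1` gives 28100 nM. For the measured compounds named here, compound 3 `O=C(CSc1ccc2ccccc2c1)Nc1ccc2nc(NC(=O)c3ccc(C(F)(F)F)cc3)sc2c1` has not yet been measured. naphthalen-2-yl in place of 3-hydroxyphenyl on a sulfur The only measured step, a 45-fold lower number from compound 1 to compound 2 (1.65 log units; beyond the scatter), also exchanged the group on this sulfur, and it was large, so this position can move the number strongly. Yet no measured compound carries naphthalen-2-yl here, and the loss of the one hydrogen-bond donor has no measured counterpart. A moderately higher number is expected for compound 3, at 1500 nM with a range from 300 nM to 8000 nM. This estimate means an expected step of a 2.4-fold higher number from compound 2 to compound 3 (0.38 log units; beyond the scatter).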

Compound 3, half-maximal inhibitory concentration: 3940 nM
For compound 3 the middle estimate is 2.6-fold (0.42 log units) below the measured one; low and high end bracket the measured number.
By their numbers in this assay, from the lowest: compound 2; then compound 3; then compound 1.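

In this assay, a carbon-only naphthalen-2-yl on this sulfur gives a 6.3-fold higher number from compound 2 to compound 3 (0.80 log units; beyond the scatter) and so falls short of 3-hydroxyphenyl. It still gives a 7.1-fold lower number from compound 1 to compound 3 (0.85 log units; beyond the scatter) and so beats pyrimidin-2-yl, which means that among these three groups a hydrogen-bond donor is not needed to improve on pyrimidin-2-yl. No evidence here explains these differences.

As far as these compounds go, the change from 3-hydroxyphenyl to naphthalen-2-yl adds a ring and removes the hydroxyl in one step, so their separate contributions remain unknown. A plain phenyl group on this sulfur would help to separate them.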